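The compounds below may be only part of what the source reports. "The series", "measured", "known", "first", "only" and "open" are said of these compounds alone.

Of the compounds shown here, three built on the same core have been tested in a functional assay on A549 cells (Homo sapiens) for cytotoxicity, read by MTT assay; a higher number here means a weaker inhibitor, a lower number a stronger inhibitor. Compound 1 `O=c1c(-c2nnc(-c3ccc(Nc4ccccc4)cc3)o2)cn(C2CC2)c2cc(N3CCNCC3)c(F)cc12` gives 52 ug/mL in this assay. Compound 2 `CCn1cc(-c2nnc(COc3cccc4ccccc34)o2)c(=O)c2cc(F)c(N3CCNCC3)cc21` gives 127 ug/mL, the highest of the three numbers shown, though compound 3 `CCn1cc(-c2nnc(Cc3ccccc3)o2)c(=O)c2cc(F)c(N3CCNCC3)cc21` at 118 ug/mL sits within the scatter of it, while the difference from compound 1 is beyond the scatter. Among the measured compounds shown here, the one step that changes this part of the molecule, a 1.1-fold lower number from compound 2 to compound 3 (0.03 log units; within the scatter), is therefore small.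

Compound 4 `CCn1cc(-c2nnc(COc3ccc4ccccc4c3)o2)c(=O)c2cc(F)c(N3CCNCC3)cc21` differs from compound 2 by naphthalen-2-yl in place of naphthalen-1-yl on an oxygen on a saturated carbon. For the measured compounds named here, no measured step addresses this particular change; since the larger swap in a 1.1-fold lower number from compound 2 to compound 3 (0.03 log units; within the scatter) stayed within the scatter, compound 4 is expected to show a step of a 1.0-fold lower number from compound 2 to compound 4 (0.01 log units; within the scatter) that likewise stays within the scatter. Compound 4 is estimated at 125 ug/mL, within 70 ug/mL to 230 ug/mL.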

Compound 4, half-maximal inhibitory concentration: 80.2 ug/mL
Compound 4: middle estimate off by 1.6-fold (0.19 log units), on the high side, within the range that was stated.
By their numbers in this assay, from the lowest: compounds 1, 4, 3 and 2 (each within the scatter of the next, the first and the last beyond it).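

In this assay, moving the attachment point of the naphthalene on the oxygen gives a 1.6-fold lower number from compound 2 to compound 4 (0.20 log units; within the scatter), so this same-atom change stays inside the scatter. Replacing the phenyl with (naphthalen-2-yl)oxy gives a 1.5-fold lower number from compound 3 to compound 4 (0.17 log units; within the scatter), so the three aromatic groups compared at this position are not separated by this read-out. No other evidence bears on this result. As far as these compounds go, it remains open whether an amine or a carboxylic acid at this position would move the number beyond the scatter. Compound 1 differs from the others in more than one place, so its lower value cannot be assigned to any single change.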